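The source may report more compounds than this note shows. Statements on the series, on what has been measured and on what is new or still open speak of the compounds shown alone.

The series begins with compound 1 `CCCNNC(=O)c1ccc(CNC(=O)c2cc3ccccc3s2)cc1`, a benzothiophene-bearing hydrazide. In an assay on isolated protein for inhibition of protein deacetylase HDAC6 (Homo sapiens), read by fluorescence, with a stated time of 2 h (a lower number here means a stronger inhibitor, a higher number a weaker inhibitor), compound 1 reaches only a limit of the assay, > 10000 nM. Compound 2 `CCCNNC(=O)c1ccc(CNC(=O)c2cc3cc(O)ccc3o2)cc1` carries a hydroxy-substituted benzofuran amide in place of that ring. In this assay compound 2 likewise returns only a limit, > 10000 nM. Where compound 2 stands is therefore plain: it sits at the top of the measured window, and so does the other value, both resting at the limit of > 10000 nM in this assay, at which 2 of the 2 values shown sit. Nothing in these two results separates one compound from the other.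

Compound 3 `CCCNNC(=O)c1ccc(CNC(=O)c2cc3cc(Br)ccc3o2)cc1` is the next structure to consider. It differs from compound 2 in one place: bromo in place of hydroxy on an aromatic carbon, on a six-membered aromatic ring of carbon only that is part of a fused system of two rings. Among the measured compounds shown here, no measured step exists for this kind of exchange, so the expectation rests only on where compound 2 stands. The step expected for this change, a step that the limit leaves unreadable from compound 2 to compound 3, is none beyond the scatter in either direction. Compound 3 is therefore estimated at 15000 nM, within a range from 4000 nM to 60000 nM.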

Compound 3, half-maximal inhibitory concentration: > 10000 nM
Compound 3: no number, only a limit; the forecaster's own chance of this, stated with the estimate: 85%; the middle value lies beyond the limit too.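

No step can be read from compound 2 to compound 3, because both compounds return only a limit in this assay: the limit of > 10000 nM in this assay, at which 3 of the 3 values shown sit.

The compounds shown leave open how strongly any of them inhibits in this assay, and whether bromo in place of hydroxy on an aromatic carbon changes that inhibition at all.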